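Replacing a methyl by benzoyloxy in a cross-conjugated dienone

The compounds below may be only part of what the source reports. "The series", "measured", "known", "first", "only" and "open" are said of these compounds alone.

Of the compounds shown here, three have been measured in a functional assay on MCF7 cells (Homo sapiens) for inhibition, read by XTT assay, with a stated time of 48 h; on this read-out higher numbers stand for weaker inhibition and lower numbers for stronger inhibition. Compound 1 `COc1ccc(C(=O)/C(=C/C2CCCCC2)CCOC(C)=O)cc1` reaches only a limit of the assay in this assay, giving > 100000 nM. Compound 2 `COc1ccc(C(=O)/C(=C/c2ccc([N+](=O)[O-])cc2)CCOC(C)=O)cc1` likewise reaches only a limit in this assay, giving > 100000 nM. The change between them, a step that the two limits leave unreadable from compound 1 to compound 2, cannot be read because both sit at the limit of > 100000 nM in this assay, at which 2 of the 3 values shown sit. Within the data shown here, compound 3 `C=C(C/C(=C\c1ccc(C)cc1)C(=O)c1ccccc1)C(=O)c1ccccc1` is the only one to give a number in this assay, 15900 nM, and so it is the sole fixed point among the values shown.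

Compound 4 `C=C(C/C(=C\c1ccc(OC(=O)c2ccccc2)cc1)C(=O)c1ccccc1)C(=O)c1ccccc1` differs from compound 3 in one place: benzoyloxy in place of methyl on an aromatic carbon, para to a large group. Among the measured compounds shown here, no measured step touches this position, and the single step available is unreadable, so no direction can be taken from the data. The step from compound 3 to compound 4 is therefore expected to be a 1.1-fold lower number from compound 3 to compound 4 (0.03 log units; within the scatter), not beyond the scatter. Compound 4 is estimated at 15000 nM, within 4000 nM to 60000 nM.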

Compound 4, half-maximal inhibitory concentration: 61600 nM
Compound 4: middle estimate off by 4.1-fold (0.61 log units), on the low side; the whole stated range lies below it.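

At this aromatic position, para to a large group, the substituent does matter: in this assay, benzoyloxy in place of methyl gives a 3.9-fold higher number from compound 3 to compound 4 (0.59 log units; beyond the scatter), the first readable step among the compounds shown. The change weakens inhibition on this read-out but does not abolish it, which no earlier comparison could show. Compound 4 still gives a number, whereas the other two values that are not numbers remain a limit of the assay: the limit of > 100000 nM in this assay, at which 2 of the 4 values shown sit.

This single pair cannot separate the effect of the added aromatic ring from that of the ester link that carries it. From the compounds shown here alone, whether a hydroxyl, a methoxy or an amine in the same place would stay close to compound 3 or shift the number further remains open, as does the outcome with a carboxylic acid there.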